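Replacing 2-Methoxyethoxy with Isobutyl in Compound 1

The compounds below may be only part of what the source reports. "The series", "measured", "known", "first", "only" and "open" are said of these compounds alone.

For the measured compounds named here, in a physicochemical assay for lipophilicity, read by HPLC, at pH 7.4 (on this read-out higher numbers stand for higher lipophilicity and lower numbers for lower lipophilicity), compound 1 (`COCCOc1cc2oc(=O)n(CCC(=O)O)c2cc1Cl`) gives 0.88, the lower of the two numbers measured so far. Compound 2 (`Cc1ccc([C@@H](C)Oc2cc3onc(CCC(=O)O)c3cc2Cl)nc1`) gives 2.42, and the gap between them lies beyond the scatter. Compound 3 (`CC(C)Cc1cc2oc(=O)n(CCC(=O)O)c2cc1Cl`) keeps the core of compound 1 but has isobutyl in place of 2-methoxyethoxy on an aromatic carbon. Going by the values given here, no measured pair differs in one place only, so the expectation rests on this structural change alone. An upward move in this assay, beyond the scatter, is expected, with the estimated step being a number 1.07 log units higher from compound 1 to compound 3 (beyond the scatter). For compound 3, the estimated value is 1.95, with an expected range of 1.45 to 2.45.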

Compound 3, distribution coefficient: 3.03
For compound 3 the middle estimate is 1.08 log units below the measured one, and the stated range ends below it.
By their numbers in this assay, from the lowest: compound 1; then compound 2; then compound 3.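

For the compounds shown here, on the aromatic carbon ortho to a chloro group, isobutyl in place of 2-methoxyethoxy gives, in this assay, a number 2.15 log units higher from compound 1 to compound 3 (beyond the scatter), the first comparison in this set that differs in one place only. It shows that, on the core of compound 1, this position can carry a large change in the read-out when an all-carbon group replaces a chain holding oxygen. Nothing measured here accounts for the size of the step. Still open, on these data alone, is how an amine or a longer ether chain at this position would read in this assay, and whether a straight butyl chain would match isobutyl.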